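The source may hold more compounds than are shown below. What is called first, only, known or untested is meant among the compounds shown, and "the series" means these compounds.

Compound 1, `COc1ccc(-c2nnc(SC/C(=N/O)c3ccccc3)n2-c2ccccc2)cc1`, gives 73% in a functional assay on the whole organism (strain albino) for inhibition, with Rattus norvegicus as the target, read by paw edema, with a stated time of 5 h, at a dose of 0.28 mmol/kg by the oral route; a higher number here means more inhibition at the dose given (going by the name of the read-out), a lower number less inhibition. Compound 2, `COc1ccc(-c2nnc(SCC(=O)c3ccccc3)n2-c2ccccc2)cc1OC`, gives 59% in this assay. Compound 3, `C=CCn1c(SCC(=O)c2ccccc2)nnc1-c1ccc(OC)c(OC)c1`, gives 62% in this assay.

Compound 1 holds the highest of the three numbers, beyond the scatter of both others. How the core of compound 1 differs from that of compound 2 is not broken down here. Compounds 2 and 3, however, differ in one place, (allyl in place of phenyl on an aromatic nitrogen), and that step is a number 3 percentage points higher from compound 2 to compound 3 (within the scatter).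

Compound 4, `C=CCn1c(SC/C(=N/O)c2ccccc2)nnc1-c1ccc(OC)cc1`, not yet measured, is related to compound 1 by the same kind of change, (allyl in place of phenyl on an aromatic nitrogen). The surroundings differ: in compound 2 the place lies next to the ring atom that bears a (benzoylmethyl)sulfanyl group and the one that bears a 3,4-dimethoxyphenyl group, while in compound 1 it lies next to the ring atom that bears a 4-methoxyphenyl group and the one that bears a large group.

Because the earlier step of a number 3 percentage points higher from compound 2 to compound 3 (within the scatter) stayed within the scatter, the step from compound 1 to compound 4 is expected to be small, about a number 2 percentage points higher from compound 1 to compound 4 (within the scatter). Compound 4 is therefore estimated at 75%, between 63% and 86%.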

Compound 4, a percentage reported as inhibition, in the whole organism at one dose (the size of the read-out at that dose, not a potency): 57%
Beside the measured number, compound 4's estimate is 18 percentage points above it; the measured number lies below the stated range.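

In this assay, allyl in place of phenyl on an aromatic nitrogen does not read the same on the two cores: the new step is a number 16 percentage points lower from compound 1 to compound 4 (beyond the scatter) and so does not repeat the earlier result. The two steps stand clearly apart: the same change on two cores in this assay, a number 3 percentage points higher (within the scatter) from compound 2 to compound 3 and a number 16 percentage points lower (beyond the scatter) from compound 1 to compound 4, 19 percentage points apart, beyond the scatter of two such steps. This shows that, in this series, the size of the change read on one core cannot simply be carried over to another, but it does not show which feature of the cores sets the two steps apart, and with a single pair on each core it gives no general rule for either.

The compounds shown carry only phenyl or allyl on that nitrogen, so it remains open how a saturated chain such as propyl, a longer chain such as butyl, or a benzyl group would read there. As far as these compounds go, it also remains open how the same change from phenyl to allyl would read on any third core.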